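Replacing 2-methylpyridin-3-yl in compound 3

The source may report more compounds than this note shows. Statements on the series, on what has been measured and on what is new or still open speak of the compounds shown alone.

Compound 1 `Cn1nccc1-c1cnc(NCc2c(F)ccc3c2CCO3)c2cn[nH]c(=O)c12`: 2.6
Compound 2 `CC(=O)N1CCC(c2cnc(NCc3c(F)ccc4c3CCO4)c3cn[nH]c(=O)c23)CC1`: 2.9
Compound 3 `Cc1ncccc1-c1cnc(NCc2c(F)ccc3c2CCO3)c2cn[nH]c(=O)c12`: 3

In a physicochemical assay for lipophilicity, using the shake flask method, in phosphate buffer, measured as octanol-water partition, with a stated time of 30 min, at pH 7.4 (on this read-out lower numbers stand for lower lipophilicity and higher numbers for higher lipophilicity), the steps leading to compound 3 are a number 0.10 log units higher from compound 2 to compound 3 (within the scatter) and a number 0.40 log units higher from compound 1 to compound 3 (beyond the scatter). Only the second separates two compounds beyond the scatter.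

Compound 4 `Cc1nn(C)cc1-c1cnc(NCc2c(F)ccc3c2CCO3)c2cn[nH]c(=O)c12` differs from compound 3 in one place: 1,3-dimethyl-1H-pyrazol-4-yl in place of 2-methylpyridin-3-yl on an aromatic carbon. Among the measured compounds shown here, no measured step makes this exact exchange. The nearest guide is a number 0.40 log units higher from compound 1 to compound 3 (beyond the scatter), read in reverse, since compound 1 also carries a pyrazolyl group, though a different one. A small fall is therefore expected. The estimated step is a number 0.30 log units lower from compound 3 to compound 4 (within the scatter). Compound 4 is estimated at 2.7, within an expected range of 2.3 to 3.1.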

Compound 4, distribution coefficient: 2.8
Compound 4: middle estimate off by 0.10 log units, on the low side; the range from low to high includes it.
By their numbers in this assay, from the lowest: compounds 1, 4, 2 and 3 (each within the scatter of the next, the first and the last beyond it).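

At this position, 1,3-dimethyl-1H-pyrazol-4-yl, a five-membered aromatic ring with 2 hetero atoms, and the six-membered 2-methylpyridin-3-yl are not told apart in this assay, with a number 0.20 log units lower from compound 3 to compound 4 (within the scatter). Compound 4 also stays close to the other two compounds, with a number 0.10 log units lower from compound 2 to compound 4 (within the scatter) and a number 0.20 log units higher from compound 1 to compound 4 (within the scatter), so the pyrazolyl exchange shows no step beyond the scatter. Nothing available explains how these groups compare.

Still open, as far as these compounds go, is how far this read-out would move with a carboxylic acid, an amine or a longer alkyl chain at this position.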